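Urea substituent change on the pyrazole urea series

The source may hold more compounds than are shown below. What is called first, only, known or untested is meant among the compounds shown, and "the series" means these compounds.

Compound 1 `CCOC(=O)c1cnn(CC(O)CC)c1NC(=O)NC(C)C` is the isopropyl urea of the shared core. In a functional assay on cells (Neutrophil, Homo sapiens) for inhibition, with a stated time of 10 min (on this read-out higher numbers stand for weaker inhibition and lower numbers for stronger inhibition), compound 1 gives > 10 nM, which is a limit of the assay rather than a number, so compound 1 is known only as the weakest-looking end of the set (the limit of > 10 nM in this assay, at which 1 of the 3 values shown sits). Two other members of the series carry aromatic groups on the urea. Compound 2 `CCOC(=O)c1cnn(CC(O)CC)c1NC(=O)Nc1cccc2ccccc12` gives 12 nM in this assay. Compound 3 `CCCC(O)Cn1ncc(C(=O)OCC)c1NC(=O)NCc1ccccc1` gives 0.43 nM in this assay; its hydroxyalkyl chain differs from that of compound 1 and compound 4, so no single step can be read from it. The change from compound 1 to compound 4 `CCOC(=O)c1cnn(CC(O)CC)c1NC(=O)NCc1ccccc1` is benzyl in place of isopropyl on an amide-type nitrogen. Within the data shown here, no directly comparable pair has been measured; the expectation is a step toward stronger inhibition, well beyond the scatter, guided by compound 3 and its 0.43 nM. Compound 4 is estimated at 1 nM, between 0.3 nM and 4 nM, an expected step of an at least 10-fold lower number from compound 1 to compound 4 (1.00 log units; beyond the scatter).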

Compound 4, half-maximal inhibitory concentration: > 10 nM
Compound 4: only a limit was reported (the forecaster's own chance of this, stated with the estimate: 10%); at least 10-fold (1.00 log units) between middle value and limit.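

With the benzyl urea held constant, hydrogen in place of methyl on a saturated chain carbon, three bonds along the chain from an oxygen on a saturated carbon, gives an at least 23-fold higher number from compound 3 to compound 4 (1.36 log units; beyond the scatter) in this assay, so in this pair the benzyl urea alone does not carry the strong inhibition and the hydroxyalkyl chain counts heavily. Compound 4 gives > 10 nM, which is a limit of the assay and not a number. The step from isopropyl to benzyl on the urea cannot be read, since both compounds stop at the same limit: the limit of > 10 nM in this assay, at which 2 of the 4 values shown sit.

On these data alone, whether benzyl in place of isopropyl changes anything on this chain stays open. Also open, as far as these compounds go, is how the benzyl urea responds to a chain longer than that of compound 3, or to a carboxylic acid in place of the ethyl ester.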